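The source may hold more compounds than are shown below. What is called first, only, known or untested is meant among the compounds shown, and "the series" means these compounds.

Of the compounds shown here, three have been measured so far, all sharing one core and differing only in the group carried on the carbonyl carbon. In an assay on SH-EP1 cells for agonist activity at Neuronal acetylcholine receptor; alpha4/beta2 (Homo sapiens), read by FLIPR and calcium flux (on this read-out higher numbers stand for larger maximal responses and lower numbers for smaller maximal responses), compound 1 `CC(=O)N1CC2CC(C1)N2` gives 94%, compound 2 `CCCC(=O)N1CC2CC(C1)N2` gives 120%, and compound 3 `O=C(C1CCC1)N1CC2CC(C1)N2` gives 100%. Compound 3 stands second highest of the three numbers: its value sits within the usual scatter of that of compound 1, while the step of a number 20 percentage points lower from compound 2 to compound 3 (beyond the scatter) lies beyond the scatter. The step of a number 6 percentage points higher from compound 1 to compound 3 (within the scatter) shows that swapping one group for another at this place need not change the response at all. Compound 4 `O=C([C@H]1C[C@H]1F)N1CC2CC(C1)N2` differs from compound 3 in one place: 2-fluorocyclopropyl in place of cyclobutyl on a carbonyl carbon. Both steps that bear on this position are modest at most, one within the scatter and one only modestly beyond it, so exchanging one small ring for another at the same place is expected to move the largest response in this assay little, if at all, and if anything slightly downward. The estimate for compound 4 in this assay is therefore 92%, with a range from 70% to 115%, which means an expected step of a number 8 percentage points lower from compound 3 to compound 4 (within the scatter).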

Compound 4, largest response reached (Emax), in percent of the reference or control that the assay uses: 110%
Compound 4: the middle estimate sits 18 percentage points below what was measured, and the stated range covers the measured number.
By their numbers in this assay, from the lowest: compounds 1, 3, 4 and 2 (each within the scatter of the next, the first and the last beyond it).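

In this assay, 2-fluorocyclopropyl is a ring group on this carbonyl carbon that clears the scatter against methyl, with a number 16 percentage points higher from compound 1 to compound 4 (beyond the scatter), whereas cyclobutyl stayed inside it, with a number 6 percentage points higher from compound 1 to compound 3 (within the scatter). Yet with a number 10 percentage points higher from compound 3 to compound 4 (within the scatter) and a number 10 percentage points lower from compound 2 to compound 4 (within the scatter), the new group cannot be told apart from either cyclobutyl or propyl, although those two groups do differ beyond the scatter. Nothing available explains this result.

From the compounds shown here alone, what plain cyclopropyl, without the fluorine, would give at this place remains open, as does the role of the two defined stereocentres in 2-fluorocyclopropyl. Also open, going by these compounds, is how the response would change with a longer chain such as pentyl, or with an amine on the group carried by the carbonyl carbon.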